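A Benzyl Ester in Place of the Aryl Ketone

The compounds below may be only part of what the source reports. "The series", "measured", "known", "first", "only" and "open" are said of these compounds alone.

Compound 1 `COc1cc2c(=O)c(C(=O)c3ccc(C)cc3)cn(Cc3ccc(Cl)cc3)c2cc1OC` and compound 2 `COc1cc2c(=O)c(C(=O)c3ccc(C)cc3)cn(Cc3ccc(C(F)(F)F)cc3F)c2cc1OC` share one core and differ only in the group on the saturated chain carbon bound to an aromatic nitrogen. In an ADME assay on Huh-7 cells (Homo sapiens) for cytotoxicity (on this read-out higher numbers stand for weaker inhibition of growth and lower numbers for stronger inhibition of growth), compound 1 gives 15500 nM. Compound 2 reaches only a limit of this assay, > 25000 nM. Within the data shown here, the single step between measured compounds, an at least 1.6-fold higher number from compound 1 to compound 2 (0.20 log units; that floor lies within the scatter), covers 2-fluoro-4-(trifluoromethyl)phenyl in place of 4-chlorophenyl on a saturated chain carbon bound to an aromatic nitrogen, and its floor sits within the scatter, as the limit of > 25000 nM in this assay, at which 1 of the 2 values shown sits, records.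

Compound 3 `COc1cc2c(=O)c(C(=O)OCc3ccccc3C)cn(Cc3ccc(C(F)(F)F)cc3F)c2cc1OC` keeps the 2-fluoro-4-(trifluoromethyl)phenyl group of compound 2 and changes a different place: (2-methylbenzyl)oxy in place of 4-methylphenyl on a carbonyl carbon. Among the measured compounds shown here, no measured step touches this carbonyl carbon, so the one known step offers no guidance on direction or size here. Compound 2 already stands at the limit, and a weaker result could not appear as a number. The step expected in this assay is a step that the limit leaves unreadable from compound 2 to compound 3, no more than the scatter. For compound 3 the estimated value is 30000 nM, within a range from 10000 nM to 100000 nM.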

Compound 3, concentration for 50% growth inhibition: 31000 nM
Compound 3: the middle estimate sits 1.0-fold (0.01 log units) below what was measured; the range from low to high includes it.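

No step can be read from compound 2 to compound 3, because the value of compound 2 is a limit and not a number: the limit of > 25000 nM in this assay, at which 1 of the 3 values shown sits.

The compounds shown leave open whether (2-methylbenzyl)oxy in place of 4-methylphenyl on a carbonyl carbon shifts the result in this assay at all, and in which direction.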